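The source may hold more compounds than are shown below. What is called first, only, known or untested is meant among the compounds shown, and "the series" means these compounds.

Of the compounds shown here, three built on one shared core have been measured in an assay on isolated protein for inhibition of Aromatase (Homo sapiens), read by fluorescence and colorimetric assay, with a stated time of 30 min; a higher number here means a weaker inhibitor, a lower number a stronger inhibitor. Compound 1 `CCCCCCCCCCc1cn(C(c2ccccc2)c2ccccc2)nn1` gives 13500 nM in this assay. Compound 2 `c1ccc(C(c2ccccc2)n2cc(C3CCCCC3)nn2)cc1` gives 13700 nM in this assay. Compound 3 `c1ccc(-c2cn(C(c3ccccc3)c3ccccc3)nn2)cc1` gives 12900 nM in this assay, and it stands level with compound 1 and compound 2, all three within the scatter of one another. Among the measured compounds shown here, the only single-change step among them, a 1.1-fold lower number from compound 2 to compound 3 (0.03 log units; within the scatter), stayed within the scatter. Compound 4 `c1ccc(OCc2cn(C(c3ccccc3)c3ccccc3)nn2)cc1` differs from compound 3 in one place: phenoxymethyl in place of phenyl on an aromatic carbon. For the measured compounds named here, no measured step covers this change; the one step known was small. The expected step is therefore a 1.0-fold higher number from compound 3 to compound 4 (0.00 log units; within the scatter), not beyond the scatter. In this assay compound 4 is estimated at 13000 nM, with a range from 5000 nM to 35000 nM.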

Compound 4, half-maximal inhibitory concentration: 31300 nM
Compound 4: middle estimate off by 2.4-fold (0.38 log units), on the low side; the measured number falls inside the stated range.
By their numbers in this assay, from the lowest: compounds 3, 1 and 2 (each within the scatter of the next); then compound 4.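

In this assay this position no longer looks indifferent to what it carries: the data show a 2.4-fold higher number from compound 3 to compound 4 (0.38 log units; beyond the scatter) and a 2.3-fold higher number from compound 2 to compound 4 (0.36 log units; beyond the scatter) and also a 2.3-fold higher number from compound 1 to compound 4 (0.37 log units; beyond the scatter) so the change goes beyond the scatter each time. Phenoxymethyl, the one group here with an oxygen, gives a weaker inhibitor than the three groups that stood level. No measured evidence explains this result.

Going by these compounds, whether the oxygen or the longer link matters stays open, and a phenylethyl group, with carbon in place of that oxygen, could separate the two. On these data alone, whether an amine here would give a stronger inhibitor also stays open.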